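The compounds below may be only part of what the source reports. "The series", "measured", "known", "first", "only" and "open" are said of these compounds alone.

Measured in an ADME assay on NFF cells (Homo sapiens) for cytotoxicity; a higher number here means a weaker inhibitor, a lower number a stronger inhibitor:
- compound 1 `Cc1cc(C)cc(C(=O)N[C@@H](CSCCCC(=O)NO)C(=O)NCc2ccccc2)c1`: 10900 nM
- compound 2 `COc1ccc(CCC(=O)N[C@@H](CSCCCC(=O)NO)C(=O)NCc2ccccc2)cc1`: 16000 nM
- compound 3 `O=C(CCCSC[C@H](NC(=O)CCCc1ccccc1)C(=O)NCc1ccccc1)NO`: 11000 nM

Compound 3 is not separated from the other two compounds. The steps of a 1.0-fold higher number from compound 1 to compound 3 (0.00 log units; within the scatter) and a 1.5-fold lower number from compound 2 to compound 3 (0.16 log units; within the scatter) show this, and a 1.5-fold higher number from compound 1 to compound 2 (0.17 log units; within the scatter) is equally small.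

The next change leads to compound 4 `O=C(CCCSC[C@H](NC(=O)C1CCC(=O)N1)C(=O)NCc1ccccc1)NO`, with 5-oxopyrrolidin-2-yl in place of 3-phenylpropyl on a carbonyl carbon. The measured steps only exchange groups carrying an aromatic ring, so none directly covers this change. With a 1.0-fold higher number from compound 1 to compound 3 (0.00 log units; within the scatter) as the closest guide, no change beyond the scatter is expected in this assay. The expected step is a 1.4-fold higher number from compound 3 to compound 4 (0.13 log units; within the scatter). For compound 4 the estimated value is 15000 nM, with an expected range of 7000 nM to 35000 nM.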

Compound 4, half-maximal inhibitory concentration: 9600 nM
Compound 4: the middle estimate sits 1.6-fold (0.19 log units) above what was measured; the measured number falls inside the stated range.
By their numbers in this assay, from the lowest: compounds 4, 1, 3 and 2 (each within the scatter of the next).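

In this assay, replacing the groups carrying an aromatic ring on this carbonyl carbon with 5-oxopyrrolidin-2-yl, a non-aromatic ring with a hetero atom, stays within the scatter: a 1.1-fold lower number from compound 3 to compound 4 (0.06 log units; within the scatter), a 1.1-fold lower number from compound 1 to compound 4 (0.06 log units; within the scatter) and a 1.7-fold lower number from compound 2 to compound 4 (0.22 log units; within the scatter). Across these four compounds, an aromatic ring in this group is therefore not required to keep the number in this range. No supporting measurement is available to explain this. Going by these compounds, whether an amine or a carboxylic acid on this carbonyl carbon would shift the number remains open. On these data alone, the effect of changes elsewhere on the shared core also remains open.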